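A Methoxy Group Added to the Benzyl Arm

The source may report more compounds than this note shows. Statements on the series, on what has been measured and on what is new or still open speak of the compounds shown alone.

Of the compounds shown here, three of one family have been tested in a functional assay on PC-3 cells (Homo sapiens) for cytotoxicity, read by MTT assay; a lower number here means a stronger inhibitor, a higher number a weaker inhibitor. Compound 1 `COc1ccc2cc([C@H](C)c3nnc(SCc4ccccc4)n3-c3ccc(Cl)cc3)ccc2c1` gives 14200 nM. Compound 2 `COc1ccc2cc([C@H](C)c3nnc(SCc4c(C)cc(C)cc4C)n3-c3cccc(Cl)c3)ccc2c1` gives 16300 nM, and compound 3 `COc1ccc2cc([C@H](C)c3nnc(SCc4c(Cl)cccc4Cl)n3-c3ccc(F)cc3)ccc2c1` gives 216000 nM. Compound 1 thus has the lowest of the three numbers; its gap to compound 2 lies within the usual scatter of repeated measurements, so no order can be claimed between those two, while compound 3 sits far beyond that scatter at a much higher number. For the measured compounds named here, no single-site step between measured compounds is available, so nothing here tells how one change alone moves the read-out.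

Compound 4 `COc1ccc(CSc2nnc([C@@H](C)c3ccc4cc(OC)ccc4c3)n2-c2ccc(Cl)cc2)cc1` has not yet been measured. It differs from compound 1 in one place: methoxy in place of hydrogen on an aromatic carbon. Going by the values given here, with no comparable step among the measured compounds to lean on, and the change limited to the benzyl group, the step from compound 1 is expected to be modest, in either direction or none beyond the scatter. The expected result is a 1.2-fold lower number from compound 1 to compound 4 (0.07 log units; within the scatter). Compound 4 is accordingly estimated at 12000 nM in this assay, with a range from 5000 nM to 30000 nM.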

Compound 4, half-maximal inhibitory concentration: <= 400000 nM
Compound 4 ended at the assay's limit; the forecaster's own chance of this, stated with the estimate: 5%; the middle value lies beyond the limit too.
By their numbers in this assay, from the lowest: compounds 1 and 2 (each within the scatter of the next); then compound 3.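

In this assay compound 4 gives <= 400000 nM, which is a limit of the assay and not a number, so no step can be read between compound 1 and compound 4. The compounds shown leave open how far methoxy in place of hydrogen on an aromatic carbon moves the read-out, or in which direction.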